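The compounds below may be only part of what the source reports. "The series", "measured", "known", "first", "only" and "open" are said of these compounds alone.

Notes on the series. Compound 1 `Cc1ccccc1-n1nncc1CN1C(=O)C2(C(C#N)=C(N)Oc3c2c2nc4ccccc4nc2c2ccccc32)c2ccccc21` and compound 2 `CCOc1ccccc1-n1nncc1CN1C(=O)C2(C(C#N)=C(N)Oc3c2c2nc4ccccc4nc2c2ccccc32)c2ccccc21` share one core; compound 3 `N#CC1=C(N)Oc2c(c3nc4ccccc4nc3c3ccccc23)C12C(=O)N(Cc1cnnn1-c1ccc(Cl)c(Cl)c1)c1ccccc12` is not yet measured. In a functional assay on A549 cells (Homo sapiens) for antiproliferative activity, read by MTT assay, with a stated time of 48 h (a lower number here means a stronger inhibitor, a higher number a weaker inhibitor), compound 1 gives only a limit, > 50000 nM. In this assay compound 2 likewise returns a limit, > 50000 nM. Going by the values given here, the single measured step, a step that the two limits leave unreadable from compound 1 to compound 2, cannot be sized because the limit of > 50000 nM in this assay, at which 2 of the 2 values shown sit, is where both values sit. Compound 2 therefore stands at the limit of this assay, with no number to place it against.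

The change to compound 3 is 3,4-dichlorophenyl in place of 2-ethoxyphenyl on an aromatic nitrogen. Among the compounds with values here, no measured step bears on a 3,4-dichlorophenyl; the only precedent is the unreadable ethoxy-for-methyl step, and it gives no size and no direction. The expectation is that compound 3 again reaches only the limit in this assay, the step that the limit leaves unreadable from compound 2 to compound 3 being estimated as nothing beyond the scatter. Compound 3 is estimated at 60000 nM, ranging from 20000 nM to 200000 nM.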

Compound 3, half-maximal inhibitory concentration: > 50000 nM
Compound 3 gave a limit, no number; the forecaster's own chance of this, stated with the estimate: 80%; the middle value does not contradict the limit.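

No step among compound 1, compound 2 and compound 3 can be read in this assay, because all three values are limits and not numbers: the limit of > 50000 nM in this assay, at which 3 of the 3 values shown sit.

The compounds shown leave open whether any group on the aromatic nitrogen gives a measurable value on the shared core.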